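This account rests on a few compounds, and the source may have more. Where it says the series, first, only, none or still open, it means among the compounds named here.

Three analogues of the shared core have been measured in an ADME assay on Huh-7 cells (Homo sapiens) for cytotoxicity; a higher number here means that more compound is tolerated, a lower number that less compound is tolerated. Compound 1, `Cc1cccc(-c2nn(-c3ccc(F)cc3F)cc2CNCCN2CCN(C)CC2)c1`, gives only a limit in this assay, > 20000 nM. Compound 2, `Cc1ccc(-c2nn(-c3ccc(F)cc3F)cc2CNCCN2CCN(C)CC2)cc1`, likewise gives only a limit in this assay, > 20000 nM. Compound 3, `CN1CCN(CCNCc2cn(-c3ccc(F)cc3F)nc2-c2ccccc2Cl)CC1`, again gives only a limit in this assay, > 20000 nM. All three values sit at the limit of > 20000 nM in this assay, at which 3 of the 3 values shown sit, so compound 3 stands level with the other two as far as these numbers can tell, and the steps a step that the two limits leave unreadable from compound 1 to compound 2, a step that the two limits leave unreadable from compound 1 to compound 3 and a step that the two limits leave unreadable from compound 2 to compound 3 cannot be read. Compound 4, `CN1CCN(CCNCc2cn(-c3ccc(F)cc3F)nc2-c2cccc(N(C)C)c2)CC1`, carries the change (3-(dimethylamino)phenyl in place of 2-chlorophenyl on an aromatic carbon). Among the measured compounds shown here, none of the measured steps reads a size, so none bears on this change beyond showing that three variants on this aromatic carbon all remain at the limit. Compound 4 is therefore expected to stay at the limit as well, with the step that the limit leaves unreadable from compound 3 to compound 4 estimated as nothing beyond the scatter. For compound 4 the value is estimated at 30000 nM, range 15000 nM to 60000 nM.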

Compound 4, half-maximal cytotoxic concentration: > 20000 nM
Compound 4: no number, only a limit (the forecaster's own chance of this, stated with the estimate: 80%); the middle value lies beyond the limit too.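

Compound 4 gives only a limit in this assay, so no step linking it to compound 1, compound 2 or compound 3 can be read: the limit of > 20000 nM in this assay, at which 4 of the 4 values shown sit.

From the compounds shown here alone, how far any of these four compounds lies beyond that limit remains open, and so does whether the groups on this aromatic carbon differ at all.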